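A Benzyl Swap Carried Over to a Weakly Active Core

The source may report more compounds than this note shows. Statements on the series, on what has been measured and on what is new or still open speak of the compounds shown alone.

Four related compounds were examined in a functional assay on DU-145 cells (Homo sapiens) for inhibition, read by trypan blue exclusion, with a stated time of 96 h; on this read-out higher numbers stand for weaker inhibition of growth and lower numbers for stronger inhibition of growth. Compound 1 `COc1ccccc1/C=C(\C(=O)c1ccc(Cl)cc1)S(=O)(=O)c1ccc(C)cc1` gives 1000 nM in this assay. Compound 2 `COc1ccccc1/C=C(\C(=O)c1ccc(Cl)cc1)S(=O)(=O)Cc1ccc(C)cc1` gives 10000 nM. The change between them is 4-methylbenzyl in place of 4-methylphenyl on a sulfonyl sulfur, and it made a 10-fold higher number from compound 1 to compound 2 (1.00 log units; beyond the scatter). Compound 3 `Cc1ccc(S(=O)(=O)/C(=C/c2c(O)cc(O)cc2O)C(=O)c2ccc(Cl)cc2)cc1` has a different core, the difference being (2,4,6-trihydroxyphenyl in place of 2-methoxyphenyl on a double-bonded chain carbon bound to a double-bonded chain carbon); that change made an at least 100-fold higher number from compound 1 to compound 3 (2.00 log units; beyond the scatter). For compound 3 this assay reports only > 100000 nM, which is a limit of the assay and not a number. Compound 4 `Cc1ccc(CS(=O)(=O)/C(=C/c2c(O)cc(O)cc2O)C(=O)c2ccc(Cl)cc2)cc1` differs from compound 3 by 4-methylbenzyl in place of 4-methylphenyl on a sulfonyl sulfur, the same change that separates compound 1 from compound 2. The step is expected to be a step that the limit leaves unreadable from compound 3 to compound 4 in this assay, resting on the earlier step, and because compound 3 already sits at the limit of > 100000 nM in this assay, at which 1 of the 3 values shown sits, compound 4 is also expected to be reported only as a limit. Compound 4 is estimated at 400000 nM.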

Compound 4, concentration for 50% growth inhibition: > 100000 nM
Compound 4: no number, only a limit (the forecaster's own chance of this, stated with the estimate: 85%); the middle value lies beyond the limit too.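

In this assay compound 4 gives > 100000 nM, which is a limit of the assay and not a number. On these data alone, compound 3 sits at the same limit, so the step between them cannot be read, and it stays unknown whether 4-methylbenzyl in place of 4-methylphenyl changes growth inhibition on this core as it did on the core of compound 1: the limit of > 100000 nM in this assay, at which 2 of the 4 values shown sit. As far as these compounds go, the change to 2,4,6-trihydroxyphenyl does carry over in direction, giving an at least 10-fold higher number from compound 2 to compound 4 (1.00 log units; beyond the scatter), but its exact size on each core remains unknown: the same change on two cores in this assay, an at least 100-fold higher number (2.00 log units; beyond the scatter) from compound 1 to compound 3 and an at least 10-fold higher number (1.00 log units; beyond the scatter) from compound 2 to compound 4; the limit leaves it open whether they differ.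

The compounds shown leave open how a longer chain such as 2-phenylethyl on the sulfonyl sulfur would behave. They also leave open whether an amine in place of the hydroxyl groups would give a value that can be read.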